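Compound 3 to compound 4: methylsulfanyl in place of methoxy

The source may hold more compounds than are shown below. What is called first, only, known or untested is meant among the compounds shown, and "the series" means these compounds.

In a functional assay on A549 cells (Homo sapiens) for antiproliferative activity, read by MTT assay, with a stated time of 72 h (a lower number here means a stronger inhibitor, a higher number a weaker inhibitor), compound 1 `COc1cc(C(=O)c2sc3ccccc3c2-c2ccccc2)cc(OC)c1OC` gives 5000 nM, compound 2 `COc1cc(C(=O)c2sc3ccccc3c2-c2ccc(C)cc2)cc(OC)c1OC` gives 7800 nM, and compound 3 `COc1ccc(-c2c(C(=O)c3cc(OC)c(OC)c(OC)c3)sc3ccccc23)cc1` gives 4400 nM. Compound 3 is not separated from the other two: its steps, a 1.1-fold lower number from compound 1 to compound 3 (0.06 log units; within the scatter) and a 1.8-fold lower number from compound 2 to compound 3 (0.25 log units; within the scatter), both lie within the scatter.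

The next compound is compound 4 `COc1cc(C(=O)c2sc3ccccc3c2-c2ccc(SC)cc2)cc(OC)c1OC`, which carries methylsulfanyl in place of methoxy on an aromatic carbon, para to a large group: methylsulfanyl in place of methoxy on an aromatic carbon.

Within the data shown here, no measured step makes this exact exchange, so the evidence is indirect. Among the measured compounds shown here, three steps bear on it, all at the same ring position: a 1.6-fold higher number from compound 1 to compound 2 (0.19 log units; within the scatter), a 1.1-fold lower number from compound 1 to compound 3 (0.06 log units; within the scatter) and a 1.8-fold lower number from compound 2 to compound 3 (0.25 log units; within the scatter). Each stays within the scatter, so hydrogen, methyl and methoxy at this position are not told apart in this assay. The series offers no sulfur-bearing comparison, and three compounds are a thin basis, so the range is kept wide.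

No step beyond the scatter is expected, and no direction is favoured; the expected step is a 1.1-fold higher number from compound 3 to compound 4 (0.06 log units; within the scatter). The estimate for compound 4 is 5000 nM, with an expected range from 2300 nM to 11000 nM.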

Compound 4, half-maximal inhibitory concentration: 5400 nM
The estimate for compound 4 lay 1.1-fold (0.03 log units) below the measured number; the range from low to high includes it.
By their numbers in this assay, from the lowest: compounds 3, 1, 4 and 2 (each within the scatter of the next).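

In this assay, among these compounds, methylsulfanyl, the first sulfur-bearing group at this position, is not told apart from the methoxy it replaces (a 1.2-fold higher number from compound 3 to compound 4 (0.09 log units; within the scatter)). It is equally not separated from methyl (a 1.4-fold lower number from compound 2 to compound 4 (0.16 log units; within the scatter)) or from hydrogen (a 1.1-fold higher number from compound 1 to compound 4 (0.03 log units; within the scatter)), so every step among the four compounds now lies within the scatter, and exchanging oxygen for sulfur in the 4-methoxyphenyl group adds no separation to the series. No supporting data accompany this result, and the flat picture at this position stays a plain observation without an explanation.

On these data alone, whether an amine, a carboxylic acid or a longer chain such as butoxy at this same position would move the number beyond the scatter remains open. All four compounds also vary at this one place only, so the compounds shown say nothing on whether substituents elsewhere on that ring, or changes to the shared core, would be tolerated in the same way.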